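Aryl ether swap at compound 3: pyridin-2-yl for 3-methylphenyl

The source may report more compounds than this note shows. Statements on the series, on what has been measured and on what is new or still open speak of the compounds shown alone.

Measured in a functional assay on Flp-In T-REx293 cells for antagonist activity at Free fatty acid receptor 1 (Homo sapiens), read by calcium flux; on this read-out higher numbers stand for weaker inhibition and lower numbers for stronger inhibition:
Compound 1 `CCCCc1ccc(NS(=O)(=O)c2ccc(F)cc2)cc1` gives 8130 nM.
Compound 2 `O=S1(=O)c2ccccc2CN1c1cccc(Oc2ccccc2)c1` gives 174 nM.
Compound 3 `Cc1cccc(Oc2cc(F)cc(N3Cc4ccccc4S3(=O)=O)c2)c1` gives 25100 nM.

Compound 3 stands at the highest number of the three in this assay, that is, the weakest inhibition. Compound 1 sits lower, and the gap is beyond the usual scatter; compound 2 sits lower still, by a wide margin that is also beyond the scatter. Among the measured compounds shown here, compound 2 and compound 3 differ in more than one place, so no single step between measured compounds is available to read the ether change on its own.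

The next compound, compound 4 `O=S1(=O)c2ccccc2CN1c1cc(F)cc(Oc2ccccn2)c1`, is compound 3 with one change: pyridin-2-yl in place of 3-methylphenyl on an oxygen on an aromatic ring. The shared core and the fluorine on its ring stay as in compound 3.

For the measured compounds named here, with no measured step of this kind on hand, the expectation rests on the values of compound 2 and compound 3 alone. A move back toward the lower number of compound 2 is expected, since the aryl ether in compound 4 is closer in size to that of compound 2, but only in part, so the step from compound 3 to compound 4 is expected as a moderate drop, a 4.2-fold lower number from compound 3 to compound 4 (0.62 log units; beyond the scatter), beyond the scatter. Compound 4 is therefore estimated at 6000 nM, within 1200 nM to 30000 nM.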

Compound 4, half-maximal inhibitory concentration: > 100000 nM
Compound 4: a limit, no number; the forecaster's own chance of this, stated with the estimate: 10%; at least 16-fold (1.22 log units) between middle value and limit.
By their numbers in this assay, from the lowest: compound 2; then compound 1; then compound 3. At a limit, above all of these: compound 4.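

In this assay compound 4 gives > 100000 nM, which is a limit of the assay and not a number. Pyridin-2-yl in place of 3-methylphenyl on an oxygen on an aromatic ring gives an at least 3.9-fold higher number from compound 3 to compound 4 (0.60 log units; beyond the scatter), the first single-place reading at this ether, and it shows that the group on this oxygen is not a silent position in the series, with this swap going toward weaker inhibition. The size of the step is only a minimum, and the true distance stays unresolved: the limit of > 100000 nM in this assay, at which 1 of the 4 values shown sits.

The swap removes the methyl and brings in the ring nitrogen with its hydrogen-bond acceptor in one move, so the compounds shown do not tell which of the two goes with the change. A methylpyridinyl group on the same oxygen would separate the two, and a carboxylic acid on this ring remains an open test of whether anything at this place brings the number back down.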